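A few compounds are considered here, and "the series" means these few. Any claim that something is new, unique, unknown or untested is made for them only; others in the source may bear on it.

Compound 1, whose structure is `COc1ccc(-c2cn(C[C@H]3c4c(ccc(O)c4C)[C@@H]4CC[C@@]5(C)C[C@]43CC5=O)nn2)cc1`, was tested in a functional assay on A549 cells (Homo sapiens) for cytotoxicity, read by MTT assay, with a stated time of 4 days; on this read-out lower numbers stand for stronger inhibition and higher numbers for weaker inhibition. In that test compound 1 gives > 20000 nM, which is a limit of the assay rather than a measured number. Compound 2, with the structure `C=C1C[C@]23C[C@@]1(O)CC[C@H]2c1cc(Br)c(O)c(C)c1[C@@H]3Cn1cc(-c2ccccc2)nn1`, gives > 20000 nM in this assay, again a limit. Compound 3, with the structure `C=C1C[C@]23C[C@@]1(O)CC[C@@H]2c1cccc(C)c1[C@@H]3Cn1cc(-c2ccc(F)cc2)nn1`, likewise gives > 20000 nM in this assay, a limit once more. All three results therefore sit at the limit of > 20000 nM in this assay, at which 3 of the 3 values shown sit, and nothing can be said about the order of the three compounds beyond the fact that each lies at that limit. Going by the values given here, no two of the measured compounds differ from each other in a single place, so no measured step in potency is available.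

The unmeasured compound 4 has the structure `Cc1c(O)ccc2c1[C@H](Cn1cc(-c3ccc(Cl)cc3)nn1)[C@@]13CC(=O)[C@@](C)(CC[C@@H]21)C3`. Compared with compound 1 the change is chloro in place of methoxy on an aromatic carbon. Nothing measured here shows what this change does in this assay. Among the compounds with values here, the only guide is compound 1, which gives > 20000 nM in this assay, a limit. Compound 4 is expected to sit at the same limit, so the step that the limit leaves unreadable from compound 1 to compound 4 is expected to be none beyond the scatter. Compound 4 is therefore estimated at 25000 nM in this assay, with a range from 8000 nM to 80000 nM.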

Compound 4, half-maximal inhibitory concentration: > 20000 nM
Compound 4 ended at the assay's limit; the forecaster's own chance of this, stated with the estimate: 75%; the middle value lies beyond the limit too.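

In this assay compound 4 gives > 20000 nM, which is a limit and not a measured number. Going by these compounds alone, compound 1 also stands at a limit, so no step between compound 1 and compound 4 can be read. The compounds shown leave open how they rank among themselves and which change to the shared core, if any, would give a measurable value: the limit of > 20000 nM in this assay, at which 4 of the 4 values shown sit.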